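The source may report more compounds than this note shows. Statements on the series, on what has been measured and on what is new or still open speak of the compounds shown alone.

Compound 1 `O=C(CSc1nc(-c2ccccc2)c(C(=O)O)c(=O)[nH]1)Nn1c(COc2ccc(Cl)cc2Cl)nc2ccccc2c1=O` and compound 2 `O=C(CSc1nc(-c2ccc(Cl)cc2)c(C(=O)O)c(=O)[nH]1)Nn1c(COc2ccc(Cl)cc2Cl)nc2ccccc2c1=O` carry a carboxylic acid on their shared core; compound 3 `Cn1c(SCC(=O)Nn2c(COc3ccc(Cl)cc3Cl)nc3ccccc3c2=O)nc(-c2ccccc2)c(C#N)c1=O` and compound 4 `Cn1c(SCC(=O)Nn2c(COc3ccc(Cl)cc3Cl)nc3ccccc3c2=O)nc(-c2ccc(Cl)cc2)c(C#N)c1=O` carry a nitrile on a methylated core. The difference between the two cores is not broken down here. In a functional assay on the whole organism (strain albino) for inhibition, with Rattus norvegicus as the target, read by paw edema, with stated times of 1 h and 2 h, at a dose of 100 mg/kg by the oral route (on this read-out lower numbers stand for less inhibition and higher numbers for more inhibition at the one dose given (going by the name of the read-out)), compound 1 gives 68.4%, compound 2 gives 61.4% and compound 3 gives 59.7%; all three lie within the scatter of one another. The change chloro in place of hydrogen on an aromatic carbon gave a number 7 percentage points lower from compound 1 to compound 2 (within the scatter). The same change, (chloro in place of hydrogen on an aromatic carbon), is made from compound 3 to compound 4 and is expected to give a step of similar size, a number 6.7 percentage points lower from compound 3 to compound 4 (within the scatter). This rests only on compound 1 and compound 2 showing a number 7 percentage points lower from compound 1 to compound 2 (within the scatter), a single occurrence. Compound 4 is accordingly estimated at 53%, with a range from 41% to 64%.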

Compound 4, a percentage reported as inhibition, in the whole organism at one dose (the size of the read-out at that dose, not a potency): 73.7%
Estimate against measurement, compound 4: 20.7 percentage points below; measured number above the stated range.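

In this assay, the step of a number 14 percentage points higher from compound 3 to compound 4 (beyond the scatter) does not repeat what the same change did on the core of compound 1. The two occurrences of phenyl to 4-chlorophenyl therefore cannot be treated as interchangeable across these cores: the same change on two cores in this assay, a number 7 percentage points lower (within the scatter) from compound 1 to compound 2 and a number 14 percentage points higher (beyond the scatter) from compound 3 to compound 4, 21 percentage points apart, beyond the scatter of two such steps. Among these compounds, this shows that the step seen on one core does not predict the step on the other here, but it does not show which difference between the cores matters, as they differ in more than one place and each contributes only one pair.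

The compounds shown leave open whether a carboxylic acid on the methylated core, or a nitrile on the unmethylated one, would follow either step. As far as these compounds go, whether fluoro or methoxy in place of chloro would behave alike on both cores also remains open.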